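Cytotoxicity notes: ester for amine on the methylene arm

The source may hold more compounds than are shown below. What is called first, only, known or untested is meant among the compounds shown, and "the series" means these compounds.

Measured so far in an ADME assay on TZM cells (Homo sapiens) for cytotoxicity, with a stated time of 1 days; on this read-out lower numbers stand for higher toxicity in this test and higher numbers for lower toxicity in this test:
compound 1 `Cc1cc(CCC#N)cc(C)c1Oc1cc(Nc2ccc(C#N)cc2)c(N)cc1C(=O)N(C)C`: 38200 nM
compound 2 `Cc1cc(CCC#N)cc(C)c1Oc1cc(Nc2ccc(C#N)cc2)c(N)cc1CNC1CC1`: 25500 nM

Within the data shown here, compound 2 holds the lowest of the two numbers in this assay; its only neighbour is compound 1, and the one measured step, a 1.5-fold lower number from compound 1 to compound 2 (0.18 log units; within the scatter), lies within the scatter. Compound 3 `Cc1cc(CCC#N)cc(C)c1Oc1cc(Nc2ccc(C#N)cc2)c(N)cc1COC(=O)C1CC1` differs from compound 2 by (cyclopropylcarbonyl)oxy in place of cyclopropylamino on a saturated chain carbon bound to an aromatic carbon. Among the measured compounds shown here, the single step measured touches this same arm but swaps an entirely different group, so it gives only a weak anchor. With no step beyond the scatter in the series, the expected move a 1.2-fold higher number from compound 2 to compound 3 (0.07 log units; within the scatter) is none beyond the scatter, and compound 3 is estimated at 30000 nM, within 12000 nM to 75000 nM.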

Compound 3, half-maximal cytotoxic concentration: 42200 nM
Estimate against measurement, compound 3: 1.4-fold (0.15 log units) below; the measured number falls inside the stated range.
By their numbers in this assay, from the lowest: compounds 2, 1 and 3 (each within the scatter of the next).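

In this assay, (cyclopropylcarbonyl)oxy in place of cyclopropylamino gives a 1.7-fold higher number from compound 2 to compound 3 (0.22 log units; within the scatter), so at this saturated chain carbon bound to an aromatic carbon, an amine link and an ester link are not told apart. Against the dimethylcarbamoyl group, ((cyclopropylcarbonyl)oxy)methyl gives a 1.1-fold higher number from compound 1 to compound 3 (0.04 log units; within the scatter), so all three groups on this aromatic carbon remain unseparated. Nothing at hand gives a reason for these read-outs. Open, as far as these compounds go, is whether a carboxylic acid or a longer alkyl chain on this arm would give a step beyond the scatter in this assay.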